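Switching the amide aryl group on a D4 agonist

A few compounds are considered here, and "the series" means these few. Any claim that something is new, unique, unknown or untested is made for them only; others in the source may bear on it.

Compound 1, `O=C(CN1CCC(c2cccc[n+]2[O-])CC1)NC1CCCCC1`, gives 294 nM in a functional assay on HEK293 cells for agonist activity at D(4) dopamine receptor (Homo sapiens), read by FLIPR; on this read-out lower numbers stand for an effect already at smaller amounts and higher numbers for an effect only at larger amounts of compound.
Compound 2, `CC(C)Oc1cccc(NC(=O)CN2CCC(c3cccc[n+]3[O-])CC2)c1`, gives 555 nM in this assay.
Compound 3, `CCc1cccc(NC(=O)CN2CCC(c3cccc[n+]3[O-])CC2)c1`, gives 95 nM in this assay.

Compound 3 has the lowest number of the three, and both gaps to it lie beyond the scatter: the step is a 3.1-fold lower number from compound 1 to compound 3 (0.49 log units; beyond the scatter) and a 5.8-fold lower number from compound 2 to compound 3 (0.77 log units; beyond the scatter). The second of these is the more telling, since it shows that the group on the aromatic ring attached to the amide nitrogen can shift the read-out a good deal.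

Compound 4, `O=C(CN1CCC(c2cccc[n+]2[O-])CC1)Nc1cccc(Cl)c1Cl`, carries a different aromatic group on that nitrogen: 2,3-dichlorophenyl in place of 3-ethylphenyl on an amide-type nitrogen. Going by the values given here, no measured pair swaps one ring substituent set for another in this way, so the measured steps only fix the scale of what such a change can do. Because a 5.8-fold lower number from compound 2 to compound 3 (0.77 log units; beyond the scatter) was modest, a step of comparable size in either direction is possible, and a large jump is not expected. The estimate for compound 4 is therefore close to compound 3, with the step expected as a 1.2-fold lower number from compound 3 to compound 4 (0.07 log units; within the scatter). Compound 4 is expected to give about 80 nM, most likely between 25 nM and 250 nM.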

Compound 4, half-maximal effective concentration: 180 nM
Beside the measured number, compound 4's estimate is 2.3-fold (0.35 log units) below it, and the stated range covers the measured number.
By their numbers in this assay, from the lowest: compounds 3, 4, 1 and 2 (each within the scatter of the next, the first and the last beyond it).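

Setting 2,3-dichlorophenyl in place of 3-ethylphenyl on the amide-type nitrogen gives a 1.9-fold higher number from compound 3 to compound 4 (0.28 log units; within the scatter) in this assay, so these two differently substituted aromatic groups cannot be told apart here, although the earlier compounds showed that a change on the aromatic ring can reach beyond the scatter. The comparison with the non-aromatic group also changes the picture: the earlier step, a 3.1-fold lower number from compound 1 to compound 3 (0.49 log units; beyond the scatter), might have suggested that an aromatic ring in place of cyclohexyl is enough to lower the number, but a 1.6-fold lower number from compound 1 to compound 4 (0.21 log units; within the scatter) shows that this does not hold for every aromatic ring, with compound 3 remaining the only one of the two aryl compounds set apart from compound 1. Nothing available explains why these steps differ in size.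

The compounds shown leave open what each chlorine contributes, and whether a single chlorine, a methoxy group or an amine on the same aromatic ring would stay within the scatter of these values. From the compounds shown here alone, all four compounds also share one core, so it remains open whether these steps would carry over to a different core.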